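From methyl to cyclopropylmethyl: compound 2 and compound 3

The source may hold more compounds than are shown below. What is called first, only, known or untested is meant among the compounds shown, and "the series" means these compounds.

Within the data shown here, only one number is available so far in an ADME assay on microsomes from liver (Rattus norvegicus) for metabolic stability, read by LC-MS, with a stated time of 1 h, at 37 degrees C, tested at 4 uM; a higher number here means that more of the compound is left, a lower number that less of the compound is left. Compound 2 (`Cn1sc2cc(OCc3cccc(-c4ccc(Cl)c(C(=O)O)c4)c3)ccc2c1=O`) gives 84%, while compound 1 (`O=C1c2ccc(OCc3cccc(-c4ccc(Cl)cc4F)c3)cc2CN1C1CCCC1`) has the entry "not determined" (no result reported). Compound 2 therefore has no measured neighbour, and its standing within the series cannot be ranked. Among the measured compounds shown here, no measured pair yet shows how a change at any point of these structures moves the read-out.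

Compound 3 (`O=C(O)c1cc(-c2cccc(COc3ccc4c(=O)n(CC5CC5)sc4c3)c2)ccc1Cl`) is the next to be read. It differs from compound 2 by cyclopropyl in place of hydrogen on a saturated chain carbon bound to an aromatic nitrogen, so that methyl becomes cyclopropylmethyl. The rest of the structure is unchanged.

For the measured compounds named here, with compound 2 at 84%, little room remains upward, so a fall is the more likely direction, although no measured step supports its size. The expected change is a number 14 percentage points lower from compound 2 to compound 3 (beyond the scatter), a moderate loss with wide uncertainty. For compound 3 the estimated value in this assay is 70%, with an expected range of 45% to 90%.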

Compound 3, percent of the compound remaining: 75%
Compound 3: the middle estimate sits 5 percentage points below what was measured, within the range that was stated.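

Among these compounds, this is the first measured pair and so the first reading at this position. In this assay, cyclopropyl in place of hydrogen on a saturated chain carbon bound to an aromatic nitrogen, the step that turns methyl into cyclopropylmethyl, comes with a number 9 percentage points lower from compound 2 to compound 3 (within the scatter), so the percent of the compound remaining does not tell the two compounds apart and this one ring can stand at this position without a separation in the read-out. Nothing on hand bears on why the read-out behaves this way at this position.

A single pair cannot show whether this holds for other groups at the same place, such as a longer straight alkyl chain, a chain ending in an amine or a chain carrying a hydroxyl group, and any of these could read differently from cyclopropylmethyl in this assay. From the compounds shown here alone, it also remains open whether the same change would read alike on a core without the carboxylic acid, as only the core shared by compound 2 and compound 3 has a measured pair.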